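Cyano in Place of Chloro at the Benzyl Ether

The source may hold more compounds than are shown below. What is called first, only, known or untested is meant among the compounds shown, and "the series" means these compounds.

Three amides sharing one core have been measured in an assay on lysate for inhibition of phosphatidylcholine:ceramide cholinephosphotransferase 2 (Homo sapiens), read by HPLC, with stated times of 30 min and 2 h; a lower number here means a stronger inhibitor, a higher number a weaker inhibitor. Compound 1 `O=C(Nc1cccnc1)c1ccccc1OCc1ccccc1` gives 3200 nM. Compound 2 `O=C(Nc1cccnc1)c1ccccc1OCc1cccc(F)c1`, carrying a fluoro on the benzyl ring, gives 1600 nM. Compound 3 `O=C(Nc1cccnc1)c1ccccc1OCc1cccc(Cl)c1`, with a chloro at that position, gives 1400 nM. Compound 3 holds the lowest of the three numbers: the step of a 2.3-fold lower number from compound 1 to compound 3 (0.36 log units; beyond the scatter) is modest and beyond the scatter, whereas the step of a 1.1-fold lower number from compound 2 to compound 3 (0.06 log units; within the scatter) is within it, so compound 3 and compound 2 cannot be told apart.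

Compound 4 `N#Cc1cccc(COc2ccccc2C(=O)Nc2cccnc2)c1` has not yet been measured. Relative to compound 3 the change is cyano in place of chloro on an aromatic carbon. Among the measured compounds shown here, no measured step replaces one substituent at this carbon with another of a different kind except a 1.1-fold lower number from compound 2 to compound 3 (0.06 log units; within the scatter), which lay within the scatter; the only larger movement among the three was a 2.3-fold lower number from compound 1 to compound 3 (0.36 log units; beyond the scatter), and that concerned adding a group where hydrogen had been. Since a substituent remains in place in compound 4, the expectation is that this assay reports no step beyond the scatter, the step of a 1.1-fold higher number from compound 3 to compound 4 (0.03 log units; within the scatter) being the estimate. Compound 4 is therefore expected to give about 1500 nM, with a range from 600 nM to 3800 nM.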

Compound 4, half-maximal inhibitory concentration: 60700 nM
Compound 4: middle estimate off by 40-fold (1.61 log units), on the low side; measured number above the stated range.
By their numbers in this assay, from the lowest: compounds 3, 2 and 1 (each within the scatter of the next, the first and the last beyond it); then compound 4.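

Fluoro and chloro could not be told apart at this carbon, yet cyano gives a 43-fold higher number from compound 3 to compound 4 (1.64 log units; beyond the scatter) and a 38-fold higher number from compound 2 to compound 4 (1.58 log units; beyond the scatter) in this assay and so shows that the number here depends strongly on which group sits on this carbon, not merely on a group being present. The change also goes beyond losing what the halogens gained: a 19-fold higher number from compound 1 to compound 4 (1.28 log units; beyond the scatter) places compound 4 past compound 1, which carries only hydrogen there, so a substituent at this carbon can move the number in either direction. Nothing measured here bears on why cyano and chloro part so sharply.

The compounds shown hold only hydrogen, fluoro, chloro and cyano at this carbon, which leaves open whether the large rise belongs to cyano alone or would also come with a methoxy group, an amine or a carboxylic acid. They also leave open whether cyano would give a similar rise on another carbon of the benzyl ring, and whether a longer chain ending in a nitrile would behave as cyano does here.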